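The source may hold more compounds than are shown below. What is called first, only, known or untested is meant among the compounds shown, and "the series" means these compounds.

For the measured compounds named here, compound 2 `CCCn1c(/N=C/c2ccc(Cl)cc2)c(C#N)sc1=S` gives the lowest of the two numbers measured in an assay on HEK293 cells for displacement of a labelled ligand from adenosine receptor A1 (Homo sapiens), read by scintillation counting, with a stated time of 60 min (a lower number here means a stronger inhibitor, a higher number a weaker inhibitor), at 2.32 nM; its only neighbour, compound 1 `CCn1c(/N=C/c2ccc(Cl)cc2)c(C#N)sc1=S`, gives 19.8 nM in this assay. Compound 3 `CCCCn1c(/N=C/c2ccc(Cl)cc2)c(C#N)sc1=S` differs from compound 2 by methyl in place of hydrogen on a saturated chain carbon, three bonds along the chain from an aromatic nitrogen. Going by the values given here, the one measured step that bears on this change is an 8.5-fold lower number from compound 1 to compound 2 (0.93 log units; beyond the scatter), which is the same kind of chain growth, ethyl to propyl there and propyl to butyl here. A further but smaller lowering is therefore expected for compound 3, with an expected step of a 1.5-fold lower number from compound 2 to compound 3 (0.19 log units; within the scatter). Compound 3 is estimated at 1.5 nM, within a range from 0.5 nM to 5 nM.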

Compound 3, inhibition constant: 24600 nM
The estimate for compound 3 lay 16000-fold (4.21 log units) below the measured number, and the stated range ends below it.
By their numbers in this assay, from the lowest: compound 2; then compound 1; then compound 3.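

In this assay, lengthening the chain on the aromatic nitrogen does not keep lowering the number: propyl to butyl gives an 11000-fold higher number from compound 2 to compound 3 (4.03 log units; beyond the scatter) and so reverses the direction of the ethyl to propyl step. Butyl also compares poorly with the shorter ethyl chain, with a 1200-fold higher number from compound 1 to compound 3 (3.09 log units; beyond the scatter) at this position, so the number does not follow chain length steadily across these compounds and propyl gives the lowest value. Nothing at hand accounts for this reversal.

Going by these compounds, it remains open whether a longer chain such as pentyl stays as weak as butyl. Also open, on these data alone, is whether a branched isobutyl group or a butyl chain ending in an amine behaves like the straight butyl chain.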